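The compounds below may be only part of what the source reports. "The series", "measured", "known", "first", "only" and "open" are said of these compounds alone.

Of the compounds shown here, two built on a shared core have so far been tested in a functional assay on A549 cells (Homo sapiens) for antiproliferative activity, read by MTT assay, with a stated time of 72 h; on this read-out higher numbers stand for weaker inhibition and lower numbers for stronger inhibition. Compound 1 `NC(=S)N1N=C(c2ccc(N3CCCCC3)cc2)CC1c1ccc(Cl)cc1` gives 33800 nM in this assay. Compound 2 `Clc1ccc(C2CC(c3ccc(N4CCCCC4)cc3)=NN2c2nc(-c3ccccc3)cs2)cc1` gives 64200 nM in this assay. Compound 2 carries the higher of the two numbers, yet the step of a 1.9-fold higher number from compound 1 to compound 2 (0.28 log units; within the scatter) is too small to tell the two apart. That single step exchanged the group on the amine nitrogen in the ring, and it says nothing directly about the change now considered.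

Compound 3 `O=[N+]([O-])c1ccc(-c2csc(N3N=C(c4ccc(N5CCCCC5)cc4)CC3c3ccc(Cl)cc3)n2)cc1` is still to be measured. It differs from compound 2 by nitro in place of hydrogen on an aromatic carbon, so that the outer phenyl becomes a 4-nitrophenyl. For the measured compounds named here, no measured pair shows a nitro group entering or leaving, so the only guide is that the one change tried so far, from compound 1 to compound 2, moved the number by less than the scatter. The expected change is a 1.3-fold lower number from compound 2 to compound 3 (0.11 log units; within the scatter), a step no larger than the scatter. On that basis compound 3 is estimated at 50000 nM, with a range from 15000 nM to 160000 nM, and the range is wide since nothing measured bears on this substitution.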

Compound 3, half-maximal inhibitory concentration: > 100000 nM
Compound 3: no number, only a limit; the forecaster's own chance of this, stated with the estimate: 15%; at least 2.0-fold (0.30 log units) between middle value and limit.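

In this assay compound 3 gives > 100000 nM, which is a limit of the assay and not a number. As far as these compounds go, the step reads an at least 1.5-fold higher number from compound 2 to compound 3 (0.19 log units; that floor lies within the scatter), so this first change on the outer phenyl shows no sign of stronger inhibition, although the true size of the step remains unknown and its floor alone cannot separate compound 3 from compound 2. What this adds to the earlier compounds is that a substituent on this aromatic carbon has now been tested, and the result for 4-nitrophenyl reaches the end of the range that the assay can report: the limit of > 100000 nM in this assay, at which 1 of the 3 values shown sits.

From the compounds shown here alone, whether an amine or a methoxy group on the same aromatic carbon would leave the number of compound 2 unchanged or lower it remains open, as does the true value of compound 3. The compounds shown also hold no second pair with and without nitro, so it is unknown whether this step would look the same on another core.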